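The compounds below may be only part of what the source reports. "The series", "measured", "known", "first", "only" and "open" are said of these compounds alone.

In an assay on cells for agonist activity at ecdysone receptor (Bombyx mori), read by a luciferase reporter, with a stated time of 24 h (a lower number here means that less compound is needed, a higher number that more compound is needed for the effect), compound 2 `CC(C)(C)N(NC(=O)c1ccccc1Cl)C(=O)c1ccccc1Cl` stands highest of the three measured compounds, at 331 nM. Compound 1 `CC(C)(C)N(NC(=O)c1ccccc1)C(=O)c1ccccc1Cl` gives 75.9 nM in this assay, and compound 3 `Cc1ccc(C(=O)NN(C(=O)c2ccccc2Cl)C(C)(C)C)cc1` gives 18.6 nM. Compound 4 `COc1ccc(C(=O)NN(C(=O)c2ccccc2Cl)C(C)(C)C)cc1` differs from compound 2 in one place: 4-methoxyphenyl in place of 2-chlorophenyl on a carbonyl carbon. Among the measured compounds shown here, two measured steps bear on this change. Adding a chloro gave a 4.4-fold higher number from compound 1 to compound 2 (0.64 log units; beyond the scatter), so that chloro goes with a higher number. Exchanging the same 2-chlorophenyl for 4-methylphenyl gave an 18-fold lower number from compound 2 to compound 3 (1.25 log units; beyond the scatter), a large step down. Since 4-methoxyphenyl likewise carries a single group on the ring and no chloro, compound 4 is expected to show a large step down, a 13-fold lower number from compound 2 to compound 4 (1.12 log units; beyond the scatter), to an estimated 25 nM, with a likely range from 8 nM to 80 nM.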

Compound 4, half-maximal effective concentration: 51.3 nM
Compound 4: the middle estimate sits 2.1-fold (0.31 log units) below what was measured, and the stated range covers the measured number.
By their numbers in this assay, from the lowest: compound 3; then compounds 4 and 1 (each within the scatter of the next); then compound 2.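

In this assay, replacing the 2-chlorophenyl on this carbonyl carbon with 4-methoxyphenyl also lowers the number, giving a 6.5-fold lower number from compound 2 to compound 4 (0.81 log units; beyond the scatter), so this drop is not confined to the 4-methylphenyl of compound 3. The group on the ring still matters: methoxy in place of methyl gives a 2.8-fold higher number from compound 3 to compound 4 (0.44 log units; beyond the scatter), whereas methoxy in place of hydrogen gives a 1.5-fold lower number from compound 1 to compound 4 (0.17 log units; within the scatter), so methoxy and hydrogen cannot be told apart here. No measurement shown explains these differences. The compounds shown leave open how an amine or a longer chain such as ethoxy would behave in place of the methoxy group.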